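A few compounds are considered here, and "the series" means these few. Any claim that something is new, unique, unknown or untested is made for them only; others in the source may bear on it.

Compound 3 `Cc1nc(S(C)(=O)=O)ccc1Oc1ncnc(OC2CCN(C(=O)SC(C)C)CC2)c1F` is the reference point of this account. For the measured compounds named here, in a functional assay on isolated protein for inhibition of Glucose-dependent insulinotropic receptor (Rattus norvegicus), read by HTRF and cAMP accumulation (on this read-out higher numbers stand for an effect only at larger amounts of compound and lower numbers for an effect already at smaller amounts), compound 3 gives 41.3 nM, the lowest of the three numbers measured so far. Compound 1 `Cc1nc(S(C)(=O)=O)ccc1Oc1ncnc(OC2CCN(C(=O)OC3CCC3)CC2)c1F` gives 167 nM in this assay, and compound 2 `Cc1nc(S(C)(=O)=O)ccc1Oc1ncnc(OC2CCN(C(=O)OC3(C(F)(F)F)COC3)CC2)c1F` gives 342 nM. The steps to compound 3 are both beyond the scatter: a 4.0-fold lower number from compound 1 to compound 3 (0.61 log units; beyond the scatter) and an 8.3-fold lower number from compound 2 to compound 3 (0.92 log units; beyond the scatter), while the step between the two carbamates is smaller, a 2.0-fold higher number from compound 1 to compound 2 (0.31 log units; beyond the scatter).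

Compound 4 `Cc1nc(S(C)(=O)=O)ccc1Oc1ncnc(OC2CCN(C(=S)OC(C)C)CC2)c1F` keeps every atom of compound 3 but joins them differently: a group of 6 heavy atoms (4 carbon, 1 oxygen, 1 sulfur; no ring) in place of a group of 6 heavy atoms (4 carbon, 1 oxygen, 1 sulfur; no ring), on an amine nitrogen in a ring. Going by the values given here, none of the measured steps reproduces this exchange. The two steps that bear on it, from compound 1 and from compound 2 to compound 3, show that moving from an oxygen-linked carbamate to the isopropylsulfanyl carbonyl lowers the number; compound 4 moves part of the way back, with the isopropyl again on oxygen and the sulfur now in the double bond. He therefore expects a step of a 1.8-fold higher number from compound 3 to compound 4 (0.26 log units; within the scatter) in this assay, a number that is somewhat higher than that of compound 3 but still well below that of compound 1. His estimate for compound 4 in this assay is 75 nM, with a range from 25 nM to 220 nM.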

Compound 4, half-maximal effective concentration: 1050 nM
Estimate against measurement, compound 4: 14-fold (1.15 log units) below; the whole stated range lies below it.
By their numbers in this assay, from the lowest: compound 3; then compound 1; then compound 2; then compound 4.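

In this assay, for the compounds shown here, the same atoms on the amine nitrogen in a ring give very different results depending on how they are joined: a 25-fold higher number from compound 3 to compound 4 (1.41 log units; beyond the scatter), a larger step than any among the earlier compounds. The result also separates sulfur as such from its arrangement, since the group with isopropyl on oxygen and sulfur in the double bond stands above both carbamates, with a 6.3-fold higher number from compound 1 to compound 4 (0.80 log units; beyond the scatter) and a 3.1-fold higher number from compound 2 to compound 4 (0.49 log units; beyond the scatter); among these four compounds, then, the presence of sulfur does not go with a low number, and compound 4 goes against any such reading. The information at hand offers nothing that accounts for this difference between the two arrangements.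

On these data alone, what stays open is how much of the low number of compound 3 depends on the isopropyl group itself, a question that a cyclobutylsulfanyl group on the same carbonyl carbon would address. Equally open, as far as these compounds go, is whether sulfur is needed on that carbonyl carbon at all, or whether an isopropylamino group there would give a number close to that of compound 3 or one closer to those of the carbamates.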